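This account rests on a few compounds, and the source may have more. Where it says the series, first, only, none or still open, it means among the compounds named here.

In an ADME assay on a cell-free system (plasma, Homo sapiens) for metabolic stability, read by LC-MS (a higher number here means that the compound lasts longer, a lower number that the compound disappears faster), compound 1 `CCCOC(=O)c1cccc(-c2cc(C(=O)Nc3ccncc3F)ccc2CN)c1` gives 0.317 h. Compound 2 `COC(=O)c1cccc(-c2cc(C(=O)Nc3ccncc3F)ccc2CN)c1` carries hydrogen in place of ethyl on a saturated chain carbon bound to an oxygen next to a carbonyl group, and in this assay compound 2 gives 1.08 h, so that this change made a 3.4-fold higher number from compound 1 to compound 2 (0.53 log units; beyond the scatter). Compound 3 `CCCOC(=O)c1cccc(-c2cc(C(=O)Nc3ccncc3)ccc2CN)c1` differs from compound 1 by hydrogen in place of fluoro on an aromatic carbon, and in this assay compound 3 gives 0.3 h, a step of a 1.1-fold lower number from compound 1 to compound 3 (0.02 log units; within the scatter). Compound 4 `COC(=O)c1cccc(-c2cc(C(=O)Nc3ccncc3)ccc2CN)c1` has not yet been measured in this assay; it differs from compound 3 by hydrogen in place of ethyl on a saturated chain carbon bound to an oxygen next to a carbonyl group, the same change that separates compound 1 from compound 2, made at the same place. Because a 1.1-fold lower number from compound 1 to compound 3 (0.02 log units; within the scatter) lies within the scatter, the two cores behave alike so far, and the new step is expected to resemble the earlier one, estimated at a 3.3-fold higher number from compound 3 to compound 4 (0.52 log units; beyond the scatter). In this assay compound 4 is therefore expected to give about 1 h, most likely between 0.5 h and 2 h.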

Compound 4, half-life: 1.52 h
Compound 4: the middle estimate sits 1.5-fold (0.18 log units) below what was measured; low and high end bracket the measured number.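

In this assay methoxycarbonyl in place of propoxycarbonyl gave a 5.1-fold higher number from compound 3 to compound 4 (0.70 log units; beyond the scatter), and this step agrees with the one on the fluoro-bearing core: the same change on two cores in this assay, a 3.4-fold higher number (0.53 log units; beyond the scatter) from compound 1 to compound 2 and a 5.1-fold higher number (0.70 log units; beyond the scatter) from compound 3 to compound 4, 1.5-fold (0.17 log units) apart, within the scatter of two such steps. Hydrogen in place of fluoro gave a 1.4-fold higher number from compound 2 to compound 4 (0.15 log units; within the scatter), which also agrees with the earlier step: the same change on two cores in this assay, a 1.1-fold lower number (0.02 log units; within the scatter) from compound 1 to compound 3 and a 1.4-fold higher number (0.15 log units; within the scatter) from compound 2 to compound 4, 1.5-fold (0.17 log units) apart, within the scatter of two such steps. The change therefore carried between these two cores in this assay, but two pairs differing only in fluoro or hydrogen do not show that it would carry to any other core.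

The compounds shown leave open where ethoxycarbonyl or a longer chain would fall. They also leave open how a carboxylic acid or an amide in place of the ester group would behave in this assay.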